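Lengthening the carbamate chain from methoxy to butoxy

The compounds below may be only part of what the source reports. "The series", "measured", "known", "first", "only" and "open" are said of these compounds alone.

Measured in a functional assay on aorta (Rattus norvegicus, strain Sprague-Dawley); a lower number here means that less compound is needed, a higher number that more compound is needed for the effect:
- compound 1 `Cc1nn(-c2ccccc2)c2nc(OCc3ccccc3F)c(-c3nc(N)c(N(C)C)c(N)n3)cc12`: 1100 nM
- compound 2 `COC(=O)Nc1c(N)nc(-c2cc3c(C)nn(-c4ccccc4)c3nc2OCc2ccccc2F)nc1N`: 5800 nM

Of these two compounds, compound 2 has the higher number, so more of it is needed for the effect. Compound 3 `CCCCOC(=O)Nc1c(N)nc(-c2cc3c(C)nn(-c4ccccc4)c3nc2OCc2ccccc2F)nc1N` differs from compound 2 in one place: propyl in place of hydrogen on a saturated chain carbon bound to an oxygen next to a carbonyl group. This turns methoxycarbonyl into butoxycarbonyl. Among the measured compounds shown here, only one measured step bears on this change, a 5.3-fold higher number from compound 1 to compound 2 (0.72 log units; beyond the scatter). That step is modest but beyond the scatter. However, it put (methoxycarbonyl)amino in place of dimethylamino, so it shows nothing about chain length. No direction can be drawn from it, and no step beyond the scatter is expected, though with wide uncertainty. The expected step is a 1.0-fold higher number from compound 2 to compound 3 (0.01 log units; within the scatter). For compound 3 the estimated value is 6000 nM, with an expected range of 1800 nM to 20000 nM.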

Compound 3, half-maximal effective concentration: > 100000 nM
Compound 3: only a limit was reported (the forecaster's own chance of this, stated with the estimate: 10%); middle value at least 16-fold (1.22 log units) from the limit.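

The earlier step swapped one kind of group for another and said nothing about chain length. Here the carbamate stays and only its chain grows: in this assay, propyl in place of hydrogen on a saturated chain carbon bound to an oxygen next to a carbonyl group gives an at least 17-fold higher number from compound 2 to compound 3 (1.23 log units; beyond the scatter), and (butoxycarbonyl)amino in place of dimethylamino gives an at least 90-fold higher number from compound 1 to compound 3 (1.95 log units; beyond the scatter), so chain length alone matters strongly at this position. Compound 3 gives only a limit, so the true size of both steps stays open at the upper end: the limit of > 100000 nM in this assay, at which 1 of the 3 values shown sits.

The compounds shown leave open whether an ethoxycarbonyl or propoxycarbonyl group would sit close to compound 2 or close to compound 3. They also leave open what a branched chain such as tert-butoxycarbonyl would give.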